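A repeated aryl change across two cores

The compounds below may be only part of what the source reports. "The series", "measured", "known", "first", "only" and "open" are said of these compounds alone.

Measured so far in a functional assay on A549 cells (Homo sapiens) for antiproliferative activity, read by MTT assay, with a stated time of 72 h; a lower number here means a stronger inhibitor, a higher number a weaker inhibitor:
Compound 1 `COc1cc2ncnc(Nc3cccc(Br)c3)c2cc1OCCCCC(=O)Nc1ccc(S(N)(=O)=O)cc1` gives 14900 nM.
Compound 2 `COc1cc2ncnc(Nc3ccc(C(F)(F)F)cc3)c2cc1OCCCCC(=O)Nc1ccc(S(N)(=O)=O)cc1` gives 14800 nM.
Compound 3 `NS(=O)(=O)c1ccc(NC(=S)Nc2ccc3ncnc(Nc4cccc(Br)c4)c3c2)cc1` gives 25000 nM.

Compound 4 `NS(=O)(=O)c1ccc(NC(=S)Nc2ccc3ncnc(Nc4ccc(C(F)(F)F)cc4)c3c2)cc1` is not yet measured. It stands to compound 3 as compound 2 stands to compound 1. In compound 4 the change is 4-(trifluoromethyl)phenyl in place of 3-bromophenyl on a nitrogen on an aromatic ring, and in compound 2 it is 4-(trifluoromethyl)phenyl in place of 3-bromophenyl on a nitrogen on an aromatic ring, the same change at the same place. In the measured pair the step was a 1.0-fold lower number from compound 1 to compound 2 (0.00 log units; within the scatter). How the core of compound 3 differs from the core of compound 1 is not broken down here; the values of compound 3 and compound 1 lie within the usual scatter of each other, so no order can be read between them. For compound 4 the expected step is no change at the digits printed from compound 3 to compound 4 (within the scatter), resting on a 1.0-fold lower number from compound 1 to compound 2 (0.00 log units; within the scatter) having stayed within the scatter. Compound 4 is therefore estimated at 25000 nM, likely between 11000 nM and 55000 nM.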

Compound 4, half-maximal inhibitory concentration: > 40000 nM
Compound 4 was reported as a limit; the forecaster's own chance of this, stated with the estimate: 10%; at least 1.6-fold (0.20 log units) between middle value and limit.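

In this assay compound 4 gives > 40000 nM, which is a limit of the assay and not a number. On the core of compound 3, the change from 3-bromophenyl to 4-(trifluoromethyl)phenyl therefore reads only as a floor, an at least 1.6-fold higher number from compound 3 to compound 4 (0.20 log units; that floor lies within the scatter). The data neither show that the change carries over from one core to the other nor show that it fails to: the same change on two cores in this assay, a 1.0-fold lower number (0.00 log units; within the scatter) from compound 1 to compound 2 and an at least 1.6-fold higher number (0.20 log units; that floor lies within the scatter) from compound 3 to compound 4; the limit leaves it open whether they differ

As far as these compounds go, the true size of the step on the core of compound 3 remains open. Also open, from the compounds shown here alone, is whether a phenyl bearing a nitrile or a chlorine in place of the bromine or the trifluoromethyl would behave alike on both cores in this assay.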